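Bifuran and bithiophene amidines against breast cancer cell growth

The source may report more compounds than this note shows. Statements on the series, on what has been measured and on what is new or still open speak of the compounds shown alone.

Measured compounds:
compound 1 `COc1ccc(-c2ccc(-c3ccc(C(=N)N)o3)o2)cc1` — 330 nM
compound 2 `N=C(N)c1ccc(-c2ccc(-c3ccc(Cl)cc3)s2)s1` — 1290 nM
compound 3 `N=C(N)c1ccc(-c2ccc(-c3cncc4ccccc34)s2)s1` — 280 nM

In a functional assay on MCF7 cells (Homo sapiens) for inhibition, read by sulforhodamine B assay, with a stated time of 48 h (a lower number here means a stronger inhibitor of growth, a higher number a weaker inhibitor of growth), compound 1 gives 330 nM, the second highest of the three numbers. Compound 3 gives 280 nM, which lies within the scatter of compound 1. Compound 2 gives 1290 nM, a number beyond the scatter from compound 1.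

Compound 4 `N=C(N)c1ccc(-c2ccc(-c3ccccc3)o2)o1` is not yet measured. It differs from compound 1 by hydrogen in place of methoxy on an aromatic carbon. Within the data shown here, no pair of measured compounds shows this change, so no step size is known for it. A change of this kind is expected to give at most a modest rise in this assay, and possibly none beyond the scatter. For compound 4 the expected value is 500 nM, with a range from 200 nM to 1300 nM. This estimate means a step of a 1.5-fold higher number from compound 1 to compound 4 (0.18 log units; within the scatter).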

Compound 4, concentration for 50% growth inhibition: 1680 nM
Compound 4: the middle estimate sits 3.4-fold (0.53 log units) below what was measured; the whole stated range lies below it.
By their numbers in this assay, from the lowest: compounds 3 and 1 (each within the scatter of the next); then compounds 2 and 4 (each within the scatter of the next).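

In this assay, hydrogen in place of methoxy gives a 5.1-fold higher number from compound 1 to compound 4 (0.71 log units; beyond the scatter), a step beyond the scatter and the first size available for any single change in this series. Among these compounds, the group on the aromatic carbon para to a large group therefore affects the number, which the earlier compounds, differing in more than one place, could not show. Nothing at hand accounts for the size of this step. Open, as far as these compounds go, is whether an amine or a longer chain at this place would match methoxy, and whether the same change gives a similar step on the core of compound 2.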